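A Larger Aryl Group in Place of 4-Fluorophenyl

A few compounds are considered here, and "the series" means these few. Any claim that something is new, unique, unknown or untested is made for them only; others in the source may bear on it.

Three measured compounds share one core and differ only on the saturated chain bound to an amide-type nitrogen. In a functional assay on NCI-H460 cells (Homo sapiens) for antiproliferative activity, read by MTT assay, with a stated time of 72 h (a higher number here means a weaker inhibitor, a lower number a stronger inhibitor), compound 1 `CNC(=O)c1cc(Oc2ccc(NC(=O)c3cc4cccnc4n(-c4ccc(F)cc4)c3=O)cc2)ccn1` gives 210 nM. Compound 2 `CCNC(=O)c1cc(Oc2ccc(NC(=O)c3cc4cccnc4n(-c4ccc(F)cc4)c3=O)cc2)ccn1` gives 220 nM in this assay, and compound 3 `CCCNC(=O)c1cc(Oc2ccc(NC(=O)c3cc4cccnc4n(-c4ccc(F)cc4)c3=O)cc2)ccn1` gives 120 nM. The three steps of a 1.0-fold higher number from compound 1 to compound 2 (0.02 log units; within the scatter), a 1.8-fold lower number from compound 1 to compound 3 (0.24 log units; within the scatter) and a 1.8-fold lower number from compound 2 to compound 3 (0.26 log units; within the scatter) all stay within the scatter, so compound 3 holds the lowest of the three numbers without standing apart from compound 1 or compound 2 beyond the scatter.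

Compound 4 `CCCNC(=O)c1cc(Oc2ccc(NC(=O)c3cc4cccnc4n(-c4ccc(C(F)(F)F)cc4Cl)c3=O)cc2)ccn1` differs from compound 3 in one place: 2-chloro-4-(trifluoromethyl)phenyl in place of 4-fluorophenyl on an aromatic nitrogen. Going by the values given here, none of the measured steps touches this aromatic nitrogen; every one of them alters the chain at the far end of the molecule, and each of those steps was small. Among the compounds with values here, there is thus no measured step that bears on the new change, and the expectation can only be anchored on the value of compound 3 with a wide range around it. Compound 4 is therefore expected to give an estimated 150 nM in this assay, with a range from 30 nM to 800 nM. The estimated step of a 1.3-fold higher number from compound 3 to compound 4 (0.10 log units; within the scatter) expresses this expectation of no direction beyond the scatter.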

Compound 4, half-maximal inhibitory concentration: 3170 nM
The estimate for compound 4 lay 21-fold (1.32 log units) below the measured number; the measured number lies above the stated range.
By their numbers in this assay, from the lowest: compounds 3, 1 and 2 (each within the scatter of the next); then compound 4.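

In this assay, the change on the aromatic nitrogen gives a 26-fold higher number from compound 3 to compound 4 (1.42 log units; beyond the scatter), a large step in the direction of a weaker inhibitor, whereas the changes to the saturated chain among compound 1, compound 2 and compound 3 all stayed within the scatter. The number therefore responds strongly at this position, at least to this one replacement, in a way that the chain steps gave no sign of. The change brings in both a chlorine and a trifluoromethyl group on the same aromatic ring, and no measurement available here bears on why the number rises.

The compounds shown leave open how much of the step goes with the chlorine and how much with the trifluoromethyl group, since the two enter together; an aryl group carrying only one of them, or a plain phenyl, would bear on that question. They also leave open whether the same replacement would give a step of similar size on the methyl or ethyl amide of compound 1 or compound 2, rather than on the propyl amide of compound 3.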